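A few compounds are considered here, and "the series" means these few. Any claim that something is new, unique, unknown or untested is made for them only; others in the source may bear on it.

Of the compounds shown here, two have been measured so far in an ADME assay on HEK-293T cells (Homo sapiens) for cytotoxicity, read by MTT assay, with a stated time of 48 h; on this read-out higher numbers stand for lower toxicity in this test and lower numbers for higher toxicity in this test. Compound 1 (`COc1ccc2c(c1)c(C1CC(c3ccc(F)cc3)=NN1C(=O)c1ccc(OC)nc1)cn2C`) gives > 300000 nM, which is a limit and not a number. Compound 2 (`COc1cccc(C2=NN(C(=O)c3ccc(C)nc3)C(c3cn(C)c4ccc(OC)cc34)C2)c1`) gives > 300000 nM, also a limit, so its place on these numbers is the limit of > 300000 nM in this assay, at which 2 of the 2 values shown sit.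

Compound 3 (`COc1cccc(C2=NN(C(=O)c3ccc(OC)nc3)C(c3cn(C)c4ccc(OC)cc34)C2)c1`) has not been measured yet. It differs from compound 2 in one place: methoxy in place of methyl on an aromatic carbon. This is methoxy in place of methyl on an aromatic carbon, which turns 6-methylpyridin-3-yl into 6-methoxypyridin-3-yl.

Within the data shown here, no measured pair shows this change on its own. Compound 1 already carries the 6-methoxypyridin-3-yl group and gives > 300000 nM, again a limit. The expectation is therefore no shift beyond the usual scatter, an estimated a number no higher from compound 2 to compound 3 (the limit leaves the size open). The assay may well report only a limit once more. Compound 3 is expected near 300000 nM, with an estimated range from 120000 nM to 700000 nM.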

Compound 3, half-maximal cytotoxic concentration: > 300000 nM
Compound 3: a limit, no number (the forecaster's own chance of this, stated with the estimate: 85%); the middle value sits exactly at the limit.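

Compound 1, compound 2 and compound 3 all report only a limit, not a number, so no step between them can be read: the limit of > 300000 nM in this assay, at which 3 of the 3 values shown sit.

Whether 6-methoxypyridin-3-yl in place of 6-methylpyridin-3-yl changes the result in this assay at all stays open, as does the size of any difference among these compounds.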